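Cytotoxicity notes: piperazine and piperidine variants of one oxazolidinone core

The source may hold more compounds than are shown below. What is called first, only, known or untested is meant among the compounds shown, and "the series" means these compounds.

Measured compounds:
compound 1, `CN1CCN(C[C@H]2CN(c3ccc(-n4cc(-c5ccccn5)cn4)c(F)c3)C(=O)O2)CC1`, 70 ug/mL
compound 2, `CCN1CCN(C[C@H]2CN(c3ccc(-n4cc(-c5ccccn5)cn4)c(F)c3)C(=O)O2)CC1`, 99 ug/mL
compound 3, `COC(=O)CC1CCN(C[C@H]2CN(c3ccc(-n4cc(-c5ccccn5)cn4)c(F)c3)C(=O)O2)CC1`, 224 ug/mL

In an ADME assay on HEK293-A cells (Homo sapiens) for cytotoxicity, read by MTT assay, with a stated time of 48 h (a higher number here means a weaker inhibitor, a lower number a stronger inhibitor), compound 3 gives the highest number of the three, with a 3.2-fold higher number from compound 1 to compound 3 (0.51 log units; beyond the scatter) and a 2.3-fold higher number from compound 2 to compound 3 (0.35 log units; beyond the scatter), both beyond the scatter; compound 1 and compound 2 sit within the scatter of each other, as a 1.4-fold higher number from compound 1 to compound 2 (0.15 log units; within the scatter) shows.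

Compound 4, `O=C1O[C@@H](CN2CCC(O)CC2)CN1c1ccc(-n2cc(-c3ccccn3)cn2)c(F)c1`, is not yet measured. It differs from compound 3 as follows: hydroxy in place of (methoxycarbonyl)methyl on a saturated ring carbon. Going by the values given here, no measured step changes only this part of the molecule. Among the compounds with values here, the steps that bear on it are those from the piperazines to compound 3, which show that swapping the whole amine ring moved the number modestly. Replacing only the substituent on the piperidine is a smaller change than either of those, so the expectation is a step within or near the scatter, with no clear direction favoured.

Compound 4 is therefore expected to give about 180 ug/mL in this assay, within a range of 80 ug/mL to 400 ug/mL, which means an estimated step of a 1.2-fold lower number from compound 3 to compound 4 (0.09 log units; within the scatter).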

Compound 4, half-maximal inhibitory concentration: > 400 ug/mL
Compound 4: only a limit was reported; the forecaster's own chance of this, stated with the estimate: 15%; middle value at least 2.2-fold (0.34 log units) from the limit.
By their numbers in this assay, from the lowest: compounds 1 and 2 (each within the scatter of the next); then compound 3. At a limit, above all of these: compound 4.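

For compound 4, this assay returns a limit and not a number: the limit of > 400 ug/mL in this assay, at which 1 of the 4 values shown sits.

On the saturated ring carbon three ring bonds from the ring nitrogen, hydroxy in place of (methoxycarbonyl)methyl gives an at least 1.7-fold higher number from compound 3 to compound 4 (0.25 log units; that floor lies within the scatter), so this floor alone does not separate the two piperidines. Exchanging the whole amine ring does separate them from the piperazines: 4-hydroxypiperidin-1-yl gives an at least 4.0-fold higher number from compound 2 to compound 4 (0.60 log units; beyond the scatter) and an at least 5.7-fold higher number from compound 1 to compound 4 (0.75 log units; beyond the scatter), wider gaps than either step to compound 3, and neither piperazine goes against this.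

Where the true number of compound 4 lies past its limit remains open, and with it whether this change moves the number beyond the scatter. Also open, from the compounds shown here alone, is how an amine or a carboxylic acid on the same ring carbon, or a longer chain ending in hydroxy, would read in this assay.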